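The compounds below may be only part of what the source reports. "The series", "measured", "known", "first", "only" and "open" are said of these compounds alone.

Compound 1 `COc1ccc(-c2cccc(C(=O)N(C)C)c2)cc1S(=O)(=O)Nc1cccc(NCCNC(=O)c2ccccc2)c1` is the starting point. In a functional assay on CHO-K1 cells for agonist activity at Orexin receptor type 2 (Homo sapiens), read by calcium flux (on this read-out lower numbers stand for smaller maximal responses and higher numbers for larger maximal responses), compound 1 gives "not active" (no number reported), so it stands without a number on this read-out. Its relative compound 2 `COc1ccc(-c2cccc(C(=O)N(C)C)c2)cc1S(=O)(=O)Nc1cccc(NCCNC(=O)c2ccccc2Cl)c1` gives 90% in this assay. Compound 3 `COc1ccc(-c2cccc(C(=O)N(C)C)c2)cc1S(=O)(=O)Nc1cccc(NCCNC(=O)c2cccc(Cl)c2)c1` carries a single change from compound 1: chloro in place of hydrogen on an aromatic carbon. Going by the values given here, no measured pair shows what a chloro in place of hydrogen does here, so the size of the step in this assay is uncertain; a rise is expected, since compound 2 shows that a chlorine on that ring can go with a large response. Compound 3 is expected to reach about 60%, within 10% to 95%.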

Compound 3, largest response reached (Emax), in percent of the reference or control that the assay uses: 78%
Estimate against measurement, compound 3: 18 percentage points below, within the range that was stated.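

In this assay, the chlorine on the benzoyl ring still allows a substantial response when it sits elsewhere: 3-chlorophenyl in place of 2-chlorophenyl gives a number 12 percentage points lower from compound 2 to compound 3 (beyond the scatter), so its place matters only modestly. Compound 1 has no number, so the steps from it to the chlorinated compounds cannot be read as sizes. Nothing available explains the difference between the two chlorine placements. As far as these compounds go, whether a fluoro, a methyl or a methoxy in place of the chloro would also give a response remains open.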